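Hydroxyphenyl hexanoyl oxazolidinone: removing the ring fluorine

The source may report more compounds than this note shows. Statements on the series, on what has been measured and on what is new or still open speak of the compounds shown alone.

Two compounds of this series carry a number. Compound 1 `CSc1cccc(CCCCCC(=O)N2CCOC2=O)c1` is tested in an assay on HEK293 cells for inhibition of N-acylethanolamine-hydrolyzing acid amidase (Rattus norvegicus), read by LC-MS, with a stated time of 30 min (on this read-out lower numbers stand for stronger inhibition and higher numbers for weaker inhibition), and compound 1 gives 12800 nM. Compound 2 `O=C(CCCCCc1ccc(O)c(F)c1)N1CCOC1=O` is tested in the same this assay and compound 2 gives 160 nM. Among the compounds with values here, compound 2 thus holds the lower of the two numbers, and the gap to compound 1 lies beyond the scatter; no single-point step between the two has been worked out, so only the two values themselves can be compared.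

Compound 3 `O=C(CCCCCc1ccc(O)cc1)N1CCOC1=O` is not yet measured. It differs from compound 2 in one place: hydrogen in place of fluoro on an aromatic carbon. The shared core and the chain are unchanged. With no measured pair of this kind in the series, the size of the step is open; a modest move toward a higher number is expected, and the expected step from compound 2 to compound 3 is a 2.0-fold higher number from compound 2 to compound 3 (0.30 log units; within the scatter), which may still fall within the scatter. Compound 3 is expected to give 320 nM in this assay, with a range from 100 nM to 1000 nM.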

Compound 3, half-maximal inhibitory concentration: 61 nM
Compound 3: middle estimate off by 5.2-fold (0.72 log units), on the high side; measured number below the stated range.
By their numbers in this assay, from the lowest: compound 3; then compound 2; then compound 1.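

In this assay, the fluoro group ortho to a hydroxy group proves dispensable for inhibition: hydrogen in place of fluoro on an aromatic carbon gives a 2.6-fold lower number from compound 2 to compound 3 (0.42 log units; beyond the scatter). Within the data shown here, this is the only single-point step so far, and although modest, it lies beyond the scatter, so the carbon bearing hydrogen is favoured over the one bearing fluoro in this structural setting. Nothing available accounts for the direction of this step, and its reason stays unassigned.

The compounds shown leave open whether chloro or methoxy on this same carbon would move the number in the same direction as hydrogen, and whether the step from fluoro to hydrogen would carry over to a longer chain. As far as these compounds go, what the hydroxy group itself contributes also stays open: only a pair with hydrogen or an amine in its place, on the otherwise unchanged structure of compound 3, could show it.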